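Shortening the Alkyl Chain on a Diaminopurine Imine

The compounds below may be only part of what the source reports. "The series", "measured", "known", "first", "only" and "open" are said of these compounds alone.

Two compounds with a shared core and a long saturated chain on a double-bonded nitrogen have been measured in a functional assay on OVCAR-3 cells (Homo sapiens) for antiproliferative activity, read by WST assay, with a stated time of 72 h; on this read-out lower numbers stand for stronger inhibition and higher numbers for weaker inhibition. Compound 1, `CCCCCCCCCCCCCCCCCC/N=c1\nc(N)c2nc[nH]c2c(N)n1`, carries an unsubstituted ring nitrogen and gives 3100 nM. Compound 2, `CCCCCCCCCCCCCC/N=c1\nc(N)c2ncn(Cc3ccccc3)c2c(N)n1`, carries a benzyl group on that ring nitrogen and a shorter chain, and in this assay compound 2 gives 5500 nM. The two numbers lie within the usual scatter of each other, so the two compounds cannot be separated on this read-out.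

Compound 3, `CCCCCCCC/N=c1\nc(N)c2ncn(Cc3ccccc3)c2c(N)n1`, has not yet been measured. It differs from compound 2 in one place: hydrogen in place of hexyl on a saturated chain carbon, eight bonds along the chain from a double-bonded nitrogen. For the measured compounds named here, no measured pair shows what such a cut in the chain does here, so the direction rests on the change alone. A marked loss of chain is expected to weaken inhibition, giving a step of a 2.7-fold higher number from compound 2 to compound 3 (0.44 log units; beyond the scatter) that is expected to reach beyond the scatter. On that basis compound 3 is estimated at 15000 nM in this assay, with a range from 5000 nM to 50000 nM.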

Compound 3, half-maximal inhibitory concentration: 4980 nM
Estimate against measurement, compound 3: 3.0-fold (0.48 log units) above, and the stated range ends above it.
By their numbers in this assay, from the lowest: compounds 1, 3 and 2 (each within the scatter of the next).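

In this assay, putting hydrogen in place of hexyl on a saturated chain carbon, eight bonds along the chain from a double-bonded nitrogen, gives a 1.1-fold lower number from compound 2 to compound 3 (0.04 log units; within the scatter). For the compounds shown here, this is the first comparison here of two compounds that differ in one place only, and it shows that removing these six carbons from the chain does not separate the two compounds on this read-out. Nothing measured alongside these numbers helps to explain the result.

This single pair cannot show whether a longer chain, an amine or a carboxylic acid at this same place would move the number beyond the usual scatter, so the tolerance seen here applies only to compound 2 and compound 3. Compound 1 differs from compound 2 in more than one place, which leaves the separate contribution of the benzyl group on the ring nitrogen unresolved, and a compound that differs from another only in that group would be needed to read it.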